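The source may hold more compounds than are shown below. What is called first, only, known or untested is meant among the compounds shown, and "the series" means these compounds.

Measured so far in an assay on isolated protein for binding affinity to leukotriene B4 receptor 1 (Homo sapiens), tested at 1 uM; on this read-out lower numbers stand for less inhibition and higher numbers for more inhibition at the one concentration tested (going by the name of the read-out):
- compound 1 `C=CCc1cc(C(C)=O)c(O)cc1OCCCCC#N` gives 57%
- compound 2 `CCc1cc(C(C)=O)c(O)cc1OCCCCC(C)(C)C#N` gives 30%
- compound 3 `CCc1cc(C(C)=O)c(O)cc1OCCCCCC(C)(C)c1nnnn1C` gives 59%

Compound 3 has the highest of the three numbers, though its reading and that of compound 1 lie within the usual scatter of each other, so no order between those two can be claimed; compound 2 sits well below both.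

The next compound, compound 4 `CCc1cc(C(C)=O)c(O)cc1OCCCCCCC(=O)Nc1nn[nH]n1`, keeps the shared core of compound 3 and changes one part of the chain: ((2H-tetrazol-5-yl)carbamoyl)methyl in place of 1-methyl-1-(1-methyl-1H-tetrazol-5-yl)ethyl on a saturated chain carbon, five bonds along the chain from an oxygen on an aromatic ring. For the measured compounds named here, no measured pair here shows this kind of exchange, so there is no step to lean on.

With only the three readings as a guide, the change from compound 3 to compound 4 is expected to give a step of a number 6 percentage points higher from compound 3 to compound 4 (within the scatter) in this assay, a shift that stays within the scatter. Compound 4 is therefore estimated at 65%, with a likely range from 35% to 90%.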

Compound 4, a percentage reported as inhibition, at one concentration (the size of the read-out at that concentration, not a potency): 83%
Estimate against measurement, compound 4: 18 percentage points below; the measured number falls inside the stated range.
By their numbers in this assay, from the lowest: compound 2; then compounds 1 and 3 (each within the scatter of the next); then compound 4.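

In this assay, the saturated chain carbon five bonds along the chain from an oxygen on an aromatic ring proves sensitive to what it carries: ((2H-tetrazol-5-yl)carbamoyl)methyl in place of 1-methyl-1-(1-methyl-1H-tetrazol-5-yl)ethyl gives a number 24 percentage points higher from compound 3 to compound 4 (beyond the scatter) in this single exchange. Both groups hold one tetrazole ring, so the ring type alone does not set the reading. Nothing available explains the step. The compounds shown do not separate the carbonyl-containing link from the loss of the methyl groups. From the compounds shown here alone, a carboxylic acid in place of the tetrazole, or a longer chain, remains open.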